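This account rests on a few compounds, and the source may have more. Where it says the series, first, only, none or still open, it means among the compounds named here.

Measured so far: compound 1 `O=C(O)COc1ccc(NC(=O)COc2ccccc2)cc1F`, in a functional assay on CHO cells for agonist activity at Free fatty acid receptor 1 (Homo sapiens), read by FLIPR; on this read-out higher numbers stand for an effect only at larger amounts of compound and lower numbers for an effect already at smaller amounts "not determined" (no result reported); compound 2 `CC(C)c1cccc(OCC(=O)Nc2ccc(OCC(=O)O)c(F)c2)c1`, 116 nM.

Within the data shown here, compound 1 carries no number in this assay, so compound 2 stands alone: in this assay compound 2 gives 116 nM, the only value shown, with nothing to compare against. Compound 3 `COc1cccc(OCC(=O)Nc2ccc(OCC(=O)O)c(F)c2)c1` differs from compound 2 in one place: methoxy in place of isopropyl on an aromatic carbon. Among the measured compounds shown here, no measured step of this kind exists here, so the size of the move in this assay is open; a modest shift toward weaker effect, somewhat beyond the scatter, is expected rather than none. For compound 3 the estimate in this assay is 260 nM, between 80 nM and 850 nM. The expected step is a 2.2-fold higher number from compound 2 to compound 3 (0.35 log units; beyond the scatter).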

Compound 3, half-maximal effective concentration: 148 nM
Compound 3: the middle estimate sits 1.8-fold (0.24 log units) above what was measured; the measured number falls inside the stated range.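

In this assay, the change at this aromatic carbon, meta to a large group, gives a 1.3-fold higher number from compound 2 to compound 3 (0.11 log units; within the scatter), so here methoxy, with its oxygen, reads the same as the all-carbon isopropyl. At this position, the difference in heavy atoms and the added hydrogen-bond acceptor leave no readable mark on the result. No evidence shown bears on why this is so.

What the compounds shown leave open is how an amine, a trifluoromethyl group or a longer chain would read at this position. On these data alone, whether this position needs any group at all also remains open.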